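Swapping a methylsulfanyl group for aminoamino on a shared core

The source may report more compounds than this note shows. Statements on the series, on what has been measured and on what is new or still open speak of the compounds shown alone.

Compound 1, `CSc1nc(-c2ccco2)c(C#N)c(=O)n1C`, gives 68 ug/mL in a functional assay, with a stated time of 20 min; a higher number here means a weaker inhibitor, a lower number a stronger inhibitor.
Compound 2, `Cn1c(NN)nc(-c2ccccc2O)c(C#N)c1=O`, gives 38 ug/mL in this assay.

Among these two numbers compound 1 holds the higher one, but the gap to compound 2 is within the scatter, so the two values cannot be told apart. Compound 3, `Cn1c(NN)nc(-c2ccco2)c(C#N)c1=O`, has not yet been measured in this assay. Its difference from compound 1 is aminoamino in place of methylsulfanyl on an aromatic carbon, the new group sitting between two ring nitrogen atoms of the shared core. Going by the values given here, no pair of measured compounds differs in just this one place, so the size of the step is unknown. Compound 2 carries the same aminoamino group and gives 38 ug/mL. On that basis the expected step is a 1.5-fold lower number from compound 1 to compound 3 (0.18 log units; within the scatter), a small move toward a slightly lower number. Compound 3 is estimated at 45 ug/mL, between 20 ug/mL and 110 ug/mL.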

Compound 3, half-maximal inhibitory concentration: 64 ug/mL
For compound 3 the middle estimate is 1.4-fold (0.15 log units) below the measured one; measured number inside the range.
By their numbers in this assay, from the lowest: compounds 2, 3 and 1 (each within the scatter of the next).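

Going by these compounds alone, this is the first direct reading of a change at this position, on an aromatic carbon between two ring nitrogen atoms of the shared core. In this assay, putting aminoamino in place of methylsulfanyl gives a 1.1-fold lower number from compound 1 to compound 3 (0.03 log units; within the scatter), so the two groups cannot be told apart here. This holds even though the change swaps carbon and sulfur for nitrogen and brings in hydrogen-bond donors that methylsulfanyl lacks. No measurement of any other kind is at hand to explain this result.

Going by these compounds, whether a simple amine, a carboxylic acid or a longer chain such as butylsulfanyl at this position would move the number beyond the scatter remains open. Also open, on these data alone, is whether the same swap would be equally small on the core of compound 2, which carries a 2-hydroxyphenyl group instead of furan-2-yl.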